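A few compounds are considered here, and "the series" means these few. Any claim that something is new, unique, unknown or untested is made for them only; others in the source may bear on it.

Working notes on the series. a functional assay on MCF7 cells (Homo sapiens) for antiproliferative activity, read by MTT assay, with a stated time of 48 h (on this read-out higher numbers stand for weaker inhibition and lower numbers for stronger inhibition), is the only read-out in hand. Compound 1 `O=C(/C=C/c1ccccc1)Nc1cc2ncnc(Nc3ccc(F)c(Cl)c3)c2s1` gives 30900 nM in this assay. Compound 2 `C#Cc1cccc(Nc2ncnc3sc(NC(=O)/C=C/c4ccccc4)cc23)c1` gives 38400 nM in this assay; the two numbers lie within the scatter of each other, so no separation between compound 1 and compound 2 can be claimed on this read-out. Compound 3 `O=C(/C=C/c1ccccc1)Nc1cc2c(Nc3ccc(F)c(Cl)c3)ncnc2s1` has not been measured. Compound 3 differs from compound 2 in one place: 3-chloro-4-fluorophenyl in place of 3-ethynylphenyl on a nitrogen on an aromatic ring. For the measured compounds named here, no measured pair in the set shows this change on its own, so the size of the step in this assay has to be guessed from what is there. Compound 1 carries the same 3-chloro-4-fluorophenyl group on a related core and gives 30900 nM, a number within the scatter of compound 2, which suggests the swap of aryl group does not move the read-out far. The step from compound 2 to compound 3 is therefore expected to be small, a 1.3-fold lower number from compound 2 to compound 3 (0.11 log units; within the scatter), within the scatter in either direction. Compound 3 is estimated at 30000 nM in this assay, with a range of 10000 nM to 90000 nM.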

Compound 3, half-maximal inhibitory concentration: 14300 nM
Beside the measured number, compound 3's estimate is 2.1-fold (0.32 log units) above it; the measured number falls inside the stated range.
By their numbers in this assay, from the lowest: compound 3; then compounds 1 and 2 (each within the scatter of the next).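

In this assay, the change at this position now has its first direct reading: 3-chloro-4-fluorophenyl in place of 3-ethynylphenyl on a nitrogen on an aromatic ring gives a 2.7-fold lower number from compound 2 to compound 3 (0.43 log units; beyond the scatter), a modest step beyond the scatter. Compound 1 and compound 2 differ in more than one place and could not isolate this change, whereas here the rest of the molecule is held constant and the two groups match in what is counted: 8 heavy atoms, one six-membered aromatic ring of carbon only, and 0 hydrogen-bond donors and acceptors. No measurement in hand accounts for the step.

Going by these compounds, whether the step follows the loss of the ethynyl group, the arrival of the chlorine or the arrival of the fluorine remains open, and a plain phenyl, a 3-chlorophenyl or a 4-fluorophenyl on the same nitrogen would separate these. For the compounds shown here, also open is whether the change has a similar size on the core of compound 1, which appears here with only the one aryl group.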